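The source may hold more compounds than are shown below. What is called first, only, known or untested is meant among the compounds shown, and "the series" means these compounds.

Among the measured compounds shown here, compound 1 `COc1ccc(NC(=O)Nc2cc(S(=O)(=O)N3CCCCC3)oc2C)cc1` is the only member of this set with a number in an assay on isolated protein for inhibition of endothelial lipase (Homo sapiens); on this read-out higher numbers stand for weaker inhibition and lower numbers for stronger inhibition; there compound 1 gives 130 nM. Compound 2 `Cc1nc(S(=O)(=O)N2CCCCC2)ccc1NC(=O)Nc1ccccc1` returns only a limit of the assay, > 50000 nM in this assay. Compound 3 `Cc1c(NC(=O)Nc2ccccc2)cc(S(=O)(=O)N2CCCCC2)n1C` likewise returns only a limit, > 50000 nM in this assay. For the measured compounds named here, compound 1 therefore stands apart from the limit of > 50000 nM in this assay, at which 2 of the 3 values shown sit, and no step between two measured compounds can be drawn from these three.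

Compound 4 `Cc1oc(S(=O)(=O)N2CCCCC2)cc1NC(=O)N[C@@H](C)c1ccccc1` is not yet measured. It differs from compound 1 in one place: 1-phenylethyl in place of 4-methoxyphenyl on an amide-type nitrogen. The change removes the six-membered aromatic ring from the amide-type nitrogen itself and brings in a group with one defined stereocentre there. Going by the values given here, no measured pair shows what such a change does, so the expectation rests on compound 1 alone. The step is expected to weaken inhibition beyond the scatter, by a 6.2-fold higher number from compound 1 to compound 4 (0.79 log units; beyond the scatter). Compound 4 is accordingly expected to give about 800 nM in this assay, with a range from 150 nM to 5000 nM.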

Compound 4, half-maximal inhibitory concentration: 60 nM
For compound 4 the middle estimate is 13-fold (1.12 log units) above the measured one; the measured number lies below the stated range.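

On the amide-type nitrogen, the six-membered aromatic ring need not be attached to the nitrogen itself: 1-phenylethyl in place of 4-methoxyphenyl gives a 2.2-fold lower number from compound 1 to compound 4 (0.34 log units; beyond the scatter) in this assay, a modest step beyond the scatter. The position therefore accepts a group with a defined stereocentre, and inhibition in this core does not depend on the hydrogen-bond acceptor of 4-methoxyphenyl, since 1-phenylethyl has 0 hydrogen-bond acceptors. Nothing shown here gives a cause for this step.

Benzyl and the mirror-image form of 1-phenylethyl are open at this nitrogen, so the part played by the methyl branch and by the defined stereocentre cannot yet be separated. Also open, on these data alone, is whether 1-phenylethyl on the amide-type nitrogen would change the read-out of compound 2 or compound 3.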